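Dropping the chloro from a coumarin isoxazole

This account rests on a few compounds, and the source may have more. Where it says the series, first, only, none or still open, it means among the compounds named here.

Compound 1 `C#CCOc1ccc2oc(=O)ccc2c1` — "not determined" (no result reported)
Compound 2 `O=c1ccc2cc(OCc3cc(-c4ccccc4Cl)no3)ccc2o1` — 18200 nM

Two compounds share the core of compound 1. In a functional assay on PC-3 cells (Homo sapiens) for cytotoxicity, read by MTT assay, with a stated time of 48 h (a lower number here means a stronger inhibitor, a higher number a weaker inhibitor), compound 2 gives 18200 nM, which is the only number shown; compound 1 was tested but gives "not determined" (no result reported), so it has no single number to report. Compound 2 therefore stands alone: it is a weak inhibitor, and nothing measured sits alongside it for comparison.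

Compound 3 `O=c1ccc2cc(OCc3cc(-c4ccccc4)no3)ccc2o1` follows from compound 2 by one change: hydrogen in place of chloro on an aromatic carbon. Read one bond further out, this is a 2-chlorophenyl becoming a plain phenyl. Within the data shown here, no pair of measured compounds shows what such a change does here, so no step size can be taken from the data. Given the weak starting point of compound 2 at 18200 nM, the expectation for compound 3 is a small step, if any, toward a weaker inhibitor, with the chance of no change beyond the usual scatter kept open. The estimated value for compound 3 in this assay is 25000 nM, with a range from 9000 nM to 70000 nM, meaning an expected step of a 1.4-fold higher number from compound 2 to compound 3 (0.14 log units; within the scatter).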

Compound 3, half-maximal inhibitory concentration: 53200 nM
Estimate against measurement, compound 3: 2.1-fold (0.33 log units) below; the measured number falls inside the stated range.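

Taking the chloro off the six-membered aromatic ring, where it sits ortho to a large group, gives a 2.9-fold higher number from compound 2 to compound 3 (0.47 log units; beyond the scatter) in this assay. Among these compounds, this is the first measured evidence that this spot on the series is not indifferent to what it carries: the step is modest but lies beyond the scatter, and compound 2, the one with the chloro, is the stronger inhibitor of the pair, even though neither compound is potent. Nothing available here says why swapping a chloro for a hydrogen moves the number in this way.

Among the compounds shown here, with only one pair of compounds, this single step cannot be taken as a rule for the series, and it cannot show whether the gain belongs to chlorine itself or would also appear with another group at this place, such as a fluoro, a methyl, a methoxy or an amine. It also leaves open how the number would respond to a chloro placed elsewhere on the phenyl, or to changes made to the shared core rather than to this ring.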